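Isobutyl for isopropyl on the carbonyl of compound 3

The compounds below may be only part of what the source reports. "The series", "measured", "known", "first", "only" and "open" are said of these compounds alone.

Within the data shown here, the three compounds measured so far share a core in which a phenol bearing a ketone is linked through a four-carbon chain to a benzoic acid. In an assay on HEK293 cells for positive allosteric modulation of metabotropic glutamate receptor 2 (Rattus norvegicus), read by thallium flux, with a stated time of 2.5 min (a higher number here means a larger maximal response, a lower number a smaller maximal response), compound 1, `Cc1c(OCCCCOCOc2ccc(C(=O)O)cc2)ccc(C(=O)CC2CCCC2)c1O`, gives 95.4%, and compound 2, `CCCC(=O)c1ccc(OCCCCOc2cccc(C(=O)O)c2C)c(C)c1O`, gives 82.4%. Compound 3, `COc1ccc(C(=O)O)cc1OCCCCOc1ccc(C(=O)C(C)C)c(O)c1C`, gives 66.6% in this assay, which is the lowest of the three numbers: compound 2 stands above it by a margin beyond the scatter, and compound 1 stands further above it, also beyond the scatter.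

Compound 4, `COc1ccc(C(=O)O)cc1OCCCCOc1ccc(C(=O)CC(C)C)c(O)c1C`, differs from compound 3 in one place: isobutyl in place of isopropyl on a carbonyl carbon. The group on the carbonyl carbon grows from three carbons to four, and it is no longer branched at the carbon attached to the carbonyl.

Among the measured compounds shown here, no step between measured compounds isolates this change, so the expectation rests on the spread of the three values. Since compound 1 gives 95.4% with a larger group on the carbonyl while compound 3 gives 66.6%, a moderate rise is expected for compound 4, of a size that may or may not clear the scatter. Compound 4 is therefore estimated at 78% in this assay, with a range from 62% to 94%. The expected step is a number 11.4 percentage points higher from compound 3 to compound 4 (beyond the scatter).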

Compound 4, largest response reached (reported as percent of maximum), in percent of the reference or control that the assay uses: 89.7%
The estimate for compound 4 lay 11.7 percentage points below the measured number; low and high end bracket the measured number.
By their numbers in this assay, from the lowest: compound 3; then compounds 2, 4 and 1 (each within the scatter of the next, the first and the last beyond it).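

In this assay, among these compounds, isobutyl in place of isopropyl on a carbonyl carbon whose other neighbour is an aromatic carbon gives a number 23.1 percentage points higher from compound 3 to compound 4 (beyond the scatter), and this is the first step that isolates one change. It shows that the maximal response is sensitive to the group at this position, even for a change from isopropylcarbonyl to isobutylcarbonyl in which no ring, hydrogen-bond donor, hydrogen-bond acceptor or net charge enters or leaves. Nothing available here accounts for the size of this step or identifies what produces it.

The change both adds a carbon and alters the branching at the carbon attached to the carbonyl, so this one step cannot separate the two, and a straight butyl chain, a neopentyl group or a longer chain on the same carbonyl would be needed to tell them apart. As far as these compounds go, it also remains open whether the same change would give a comparable step with the substituted benzoic acid and linker of compound 1 or compound 2 in place of those shared by compound 3 and compound 4.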